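A few compounds are considered here, and "the series" means these few. Any claim that something is new, unique, unknown or untested is made for them only; others in the source may bear on it.

Of the compounds shown here, three sharing one core have been measured in a functional assay on SW480 cells (Homo sapiens) for antiproliferative activity, read by MTT assay, with a stated time of 48 h; on this read-out higher numbers stand for weaker inhibition and lower numbers for stronger inhibition. Compound 1 (`CC(C)=CCC[C@]1(C)/C=C/[C@@H](OC(=O)C=C(C)C)[C@](C)(O)/C=C/C(=O)/C(CN(C)C)=C\C1`), with dimethylamino on a saturated chain carbon, gives 480 nM. Compound 2 (`CC(C)=CCC[C@]1(C)/C=C/[C@@H](OC(=O)C=C(C)C)[C@](C)(O)/C=C/C(=O)/C(CN2CCCC2)=C\C1`), with pyrrolidin-1-yl there, gives 310 nM. Compound 3 (`CC(C)=CCC[C@]1(C)/C=C/[C@@H](OC(=O)C=C(C)C)[C@](C)(O)/C=C/C(=O)/C(CN2CCN(C)CC2)=C\C1`), with 4-methylpiperazin-1-yl there, gives 800 nM. Compound 3 cannot be told apart from compound 1, as a 1.7-fold higher number from compound 1 to compound 3 (0.22 log units; within the scatter) shows, but it has the higher number against compound 2, with a 2.6-fold higher number from compound 2 to compound 3 (0.41 log units; beyond the scatter).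

Compound 4 (`CO/N=C/C1=C/C[C@](C)(CCC=C(C)C)/C=C/[C@@H](OC(=O)C=C(C)C)[C@](C)(O)/C=C/C1=O`) changes the same site of the core, on a double-bonded ring carbon: a group of 4 heavy atoms (2 carbon, 1 nitrogen, 1 oxygen; no ring) in place of a group of 8 heavy atoms (6 carbon, 2 nitrogen; one six-membered non-aromatic ring with 2 hetero atoms), on a double-bonded ring carbon. The measured steps bear on this only in part. Each replaces one amine group with another, and the remaining one, a 1.5-fold lower number from compound 1 to compound 2 (0.19 log units; within the scatter), is also small. Among the measured compounds shown here, none of them removes the whole (4-methylpiperazin-1-yl)methyl group, and no measured compound carries a group without nitrogen in a ring or chain amine at this site. For the measured compounds named here, the data therefore give no direction for the step, and the largest measured step, a 2.6-fold higher number from compound 2 to compound 3 (0.41 log units; beyond the scatter), sets only a rough scale. The estimate is a 1.3-fold higher number from compound 3 to compound 4 (0.10 log units; within the scatter), an expected step that need not exceed the scatter. For compound 4 the expected value in this assay is 1000 nM, with an estimated range from 250 nM to 4000 nM.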

Compound 4, half-maximal inhibitory concentration: 2630 nM
Beside the measured number, compound 4's estimate is 2.6-fold (0.42 log units) below it, and the stated range covers the measured number.
By their numbers in this assay, from the lowest: compounds 2, 1 and 3 (each within the scatter of the next, the first and the last beyond it); then compound 4.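

In this assay, compound 4 is the only one shown that carries no amine at this double-bonded ring carbon, and the change lies beyond the scatter against all three amines: (a 3.3-fold higher number from compound 3 to compound 4 (0.52 log units; beyond the scatter)), (a 5.5-fold higher number from compound 1 to compound 4 (0.74 log units; beyond the scatter)) and (an 8.5-fold higher number from compound 2 to compound 4 (0.93 log units; beyond the scatter)). Each of these steps is larger than any step among the amines themselves, so the number at this site moved further on leaving the amine series than on exchanging one amine for another. Heavy-atom count alone does not set the number here, as the step from the dimethylamino compound replaces one group of 4 heavy atoms with another and is still beyond the scatter. No evidence is available to explain the change.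

Going by these compounds, it remains open whether the higher number follows from the loss of the amine or from the particular group that entered, a question that a hydroxymethyl or morpholin-4-ylmethyl group at this carbon could help to settle. On these data alone, how a primary amine, or a longer chain ending in an amine, would stand against the three amines also remains open.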